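Removing a pyridin-3-yl group from compound 2

A few compounds are considered here, and "the series" means these few. Any claim that something is new, unique, unknown or untested is made for them only; others in the source may bear on it.

Measured compounds:
compound 1, `O=C(Nc1ccc(Cl)c(Br)c1)c1cc(Cl)ccc1O`, 680 nM
compound 2, `N#Cc1ccc(NC(=O)c2cc(-c3cccnc3)ccc2O)cc1`, 8330 nM
compound 3, `O=C(Nc1cc(C(F)(F)F)cc(C(F)(F)F)c1)c1cc(F)ccc1O`, 470 nM

All three numbers come from a functional assay on KG-1 cells (Homo sapiens) for cytotoxicity, read by luminescence and CellTiter-Glo, with a stated time of 3 days; on this read-out higher numbers stand for weaker inhibition and lower numbers for stronger inhibition. Compound 2 gives the highest of the three numbers in this assay, that is, the weakest inhibition among them. Its nearest neighbour is compound 1, whose number is lower by an amount beyond the scatter, and compound 3 lies further still, also beyond the scatter. No two of these compounds differ in only one place, so the gaps between them cannot be tied to a single group.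

Compound 4 has the structure `N#Cc1ccc(NC(=O)c2ccccc2O)cc1` and has not yet been measured in this assay. It differs from compound 2 as follows:

hydrogen in place of pyridin-3-yl on an aromatic carbon

Among the compounds with values here, no step between measured compounds is available to calibrate this change. Compound 1 and compound 3, which carry no pyridin-3-yl group, both give lower numbers than compound 2, but they differ from it in several other places as well. A modest move toward a lower number is expected, though one that may not exceed the scatter: the estimated step is a 1.5-fold lower number from compound 2 to compound 4 (0.18 log units; within the scatter). For compound 4 the expected value in this assay is 5500 nM, with a likely range from 1800 nM to 17000 nM.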

Compound 4, half-maximal inhibitory concentration: 5370 nM
Estimate against measurement, compound 4: 1.0-fold (0.01 log units) above, within the range that was stated.
By their numbers in this assay, from the lowest: compounds 3 and 1 (each within the scatter of the next); then compounds 4 and 2 (each within the scatter of the next).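

In this assay hydrogen in place of pyridin-3-yl gives a 1.6-fold lower number from compound 2 to compound 4 (0.19 log units; within the scatter) and so the two compounds cannot be told apart on this read-out. Within the data shown here, this is the first comparison in the set that changes only one place, here an aromatic carbon para to a hydroxy group, and it shows that a whole six-membered aromatic ring of 6 heavy atoms can leave that carbon with no change that stands clear of the usual scatter. For this pair, then, the presence or absence of the pyridin-3-yl group makes no readable difference to the number, but no measurement at hand explains why that should be so.

As far as these compounds go, with only hydrogen and pyridin-3-yl compared on this carbon, it stays open whether a different group there, such as an amine, a carboxylic acid or a simple methyl, would move the number beyond the scatter. The compounds shown also offer no single-place step for any other part of the molecule, so what the nitrile of compound 4 contributes to its number remains unknown.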